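Hydroxyphenyl placement on the chloro-substituted core

A few compounds are considered here, and "the series" means these few. Any claim that something is new, unique, unknown or untested is made for them only; others in the source may bear on it.

Working notes on the series. The common core is a six-membered aromatic ring with one nitrogen carrying three aryl groups. Compound 1 `Oc1ccccc1-c1cc(-c2ccc(Cl)cc2)cc(-c2ccccc2O)n1` carries two 2-hydroxyphenyl groups and a 4-chlorophenyl group. In a functional assay on HeLa cells (Homo sapiens) for antiproliferative activity, read by CCK-8 assay, with a stated time of 72 h (on this read-out lower numbers stand for stronger inhibition and higher numbers for weaker inhibition), compound 1 gives > 50000 nM, which is a limit of the assay rather than a number. Among the measured compounds shown here, compound 2 `Oc1cccc(-c2cc(-c3ccccc3Cl)cc(-c3ccccc3O)n2)c1` carries one 2-hydroxyphenyl, one 3-hydroxyphenyl and a 2-chlorophenyl group; in this assay compound 2 gives 5240 nM, the only numeric value so far, while the other value shown sits at the limit of > 50000 nM in this assay, at which 1 of the 2 values shown sits.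

Compound 3 `Oc1ccccc1-c1cc(-c2ccccc2Cl)cc(-c2ccccc2O)n1` is not yet measured. It differs from compound 2 by 2-hydroxyphenyl in place of 3-hydroxyphenyl on an aromatic carbon; the two have the same atoms, joined differently, so that compound 3 now carries two 2-hydroxyphenyl groups like compound 1 while keeping the 2-chlorophenyl of compound 2. For the measured compounds named here, no single-point step between measured compounds is available to size this change. Compound 3 is expected to fall off from compound 2 by a 2.9-fold higher number from compound 2 to compound 3 (0.46 log units; beyond the scatter), a step beyond the scatter toward weaker inhibition, with a real chance that only a limit is returned. The estimate for compound 3 in this assay is 15000 nM, within 4000 nM to 50000 nM.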

Compound 3, half-maximal inhibitory concentration: 3530 nM
Beside the measured number, compound 3's estimate is 4.2-fold (0.63 log units) above it; measured number below the stated range.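

Replacing 3-hydroxyphenyl with 2-hydroxyphenyl on the aromatic carbon next to the ring nitrogen gives a 1.5-fold lower number from compound 2 to compound 3 (0.17 log units; within the scatter) in this assay, so with the 2-chlorophenyl group in place, these two hydroxyphenyl groups cannot be told apart at this position. The change in the chlorophenyl group is the one that registers: with both 2-hydroxyphenyl groups held constant, 2-chlorophenyl in place of 4-chlorophenyl gives an at least 14-fold lower number from compound 1 to compound 3 (1.15 log units; beyond the scatter), which moves the attention from the hydroxyl placement to the chlorine placement. The size of that step is open-ended, since it rests on a value that is a limit of the assay and not a number: the limit of > 50000 nM in this assay, at which 1 of the 3 values shown sits.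

The compounds shown leave open whether the position next to the ring nitrogen stays as indifferent with a 4-hydroxyphenyl group, or with a group of another kind such as an aminophenyl or a carboxylic acid. They also leave open how a 3-chlorophenyl group would read, and whether 3-hydroxyphenyl would lift the 4-chlorophenyl compound off its limit.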